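Removing One Fluoro on the Sulfonyl Aryl Ring

The source may hold more compounds than are shown below. What is called first, only, known or untested is meant among the compounds shown, and "the series" means these compounds.

Measured so far:
Compound 1 `Cc1cn(Cc2ccc(Cl)cc2Cl)c2c(-c3nnc(NS(=O)(=O)c4cc(F)c(F)cc4F)o3)cc(F)cc12` gives 2 nM in an assay on isolated protein for displacement of a labelled ligand from prostaglandin E2 receptor EP3 subtype (Homo sapiens); on this read-out higher numbers stand for weaker inhibition and lower numbers for stronger inhibition.
Compound 2 `Cc1cn(Cc2ccc3ccccc3c2)c2c(-c3cc(NS(=O)(=O)c4ccc(F)c(F)c4)no3)cc(F)cc12` gives 1 nM in this assay.

Of these two numbers, compound 1 holds the higher one, but its distance from compound 2 lies within the scatter, so the two cannot be ranked. Compound 3 `Cc1cn(Cc2ccc(Cl)cc2Cl)c2c(-c3nnc(NS(=O)(=O)c4ccc(F)c(F)c4)o3)cc(F)cc12` is not yet measured. It differs from compound 1 in one place: hydrogen in place of fluoro on an aromatic carbon. For the measured compounds named here, no step between measured compounds bears on this change. Compound 2 carries the same (3,4-difluorophenyl)sulfonyl group on another core, and in this assay compound 2 gives 1 nM, close to compound 1. On that basis compound 3 is expected to show a step of no change at the digits printed from compound 1 to compound 3 (within the scatter), none beyond the scatter. Compound 3 is estimated at 2 nM, within 0.7 nM to 6 nM.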

Compound 3, half-maximal inhibitory concentration: 20 nM
The estimate for compound 3 lay 10-fold (1.00 log units) below the measured number; measured number outside the range, above it.
By their numbers in this assay, from the lowest: compounds 2 and 1 (each within the scatter of the next); then compound 3.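

In this assay, the fluoro ortho to a large group on the sulfonyl aryl ring proves not to be interchangeable with hydrogen: going from 2,4,5-trifluorophenyl to 3,4-difluorophenyl gives a 10-fold higher number from compound 1 to compound 3 (1.00 log units; beyond the scatter). For the compounds shown here, this single pair is the first direct reading of this position, and it shows that one fluoro there matters on this core. Nothing at hand accounts for the step.

Going by these compounds, whether a methoxy group in that place would keep the number of compound 1 stays open. So does whether the same change gives a step of similar size on another core.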